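A few compounds are considered here, and "the series" means these few. Any claim that something is new, unique, unknown or untested is made for them only; others in the source may bear on it.

Measured so far in a functional assay on MIA PaCa-2 cells (Homo sapiens) for cytotoxicity, read by WST assay, with a stated time of 48 h; a higher number here means a weaker inhibitor, a lower number a stronger inhibitor:
- compound 1 `N#C/C(=C\c1cn(Cc2ccc(Cl)cc2)c2ccccc12)C(=O)c1c[nH]c2cc(F)ccc12`: 16600 nM
- compound 2 `N#C/C(=C\c1c[nH]c2ccccc12)C(=O)c1c[nH]c2ccccc12`: 36800 nM

Compound 1 has the lower number of the two, so it is the stronger inhibitor here, and its gap to compound 2 lies beyond the usual scatter. Among the compounds with values here, with only two values, this places compound 1 at the better end of a very short series. The two compounds differ in more than one place, so their gap says nothing about the next change.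

Next is compound 3 `COc1ccc2c(C(=O)/C(C#N)=C/c3cn(Cc4ccc(Cl)cc4)c4ccccc34)c[nH]c2c1`, which keeps the core of compound 1 and differs from it by methoxy in place of fluoro on an aromatic carbon. The same change reads as 6-fluoro-1H-indol-3-yl to 6-methoxy-1H-indol-3-yl. Within the data shown here, no measured pair isolates this swap, so the only anchor is compound 1 at 16600 nM. In this assay no change beyond the scatter is expected, and the estimated step is a 1.1-fold higher number from compound 1 to compound 3 (0.04 log units; within the scatter). For compound 3 the expected value is 18000 nM, with an estimated range of 7000 nM to 45000 nM.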

Compound 3, half-maximal inhibitory concentration: 40400 nM
Beside the measured number, compound 3's estimate is 2.2-fold (0.35 log units) below it; the measured number falls inside the stated range.
By their numbers in this assay, from the lowest: compound 1; then compounds 2 and 3 (each within the scatter of the next).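

In this assay, the change from 6-fluoro-1H-indol-3-yl to 6-methoxy-1H-indol-3-yl gives the series its first reading of a single change: a 2.4-fold higher number from compound 1 to compound 3 (0.39 log units; beyond the scatter), a modest step that lies beyond the scatter. This position on the six-membered aromatic ring is therefore not indifferent to its substituent, and with the rest of compound 1 held fixed, fluoro gives the stronger inhibitor of the pair. Nothing available accounts for the size or direction of this step.

Still open, as far as these compounds go, is whether the step belongs to methoxy specifically or would also appear with other groups at this position, such as a hydrogen, a chlorine, a hydroxy group, an amine or a longer ethoxy chain. A single pair also leaves open whether methoxy in place of fluoro would give a similar step with another group in place of the one carried on the ring nitrogen elsewhere in compound 1.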